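The source may hold more compounds than are shown below. What is called first, only, known or untested is meant among the compounds shown, and "the series" means these compounds.

In an ADME assay on microsomes from liver (Mus musculus) for metabolic stability, using NADPH, with a stated time of 10 min (a higher number here means that more of the compound is left, a lower number that less of the compound is left), the measured compounds are:
Compound 1 `CN(C[C@H]1Cc2c(cccc2N2CCC(N)CC2)CN1)[C@H]1CCCc2cccnc21`: 70.3%
Compound 2 `CN(C[C@H]1Cc2c(cccc2N2C[C@H]3CNC[C@H]3C2)CN1)[C@H]1CCCc2cccnc21`: 54.7%
Compound 3 `CN(C)[C@H]1CCN(c2cccc3c2C[C@H](CN(C)[C@H]2CCCc4cccnc42)NC3)C1`: 18.5%

Compound 3 stands lowest of the three in this assay. The steps down to it are a number 36.2 percentage points lower from compound 2 to compound 3 (beyond the scatter) and a number 51.8 percentage points lower from compound 1 to compound 3 (beyond the scatter).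

Next is compound 4 `CN(C)[C@@H]1CCN(c2cccc3c2C[C@H](CN(C)[C@H]2CCCc4cccnc42)NC3)C1`, and the structural change is: the two compounds have the same atoms and bonds and differ only in configuration as drawn: 1 of 3 stereo elements differ; a stereocentre at a saturated ring carbon is drawn S in compound 3 and R in compound 4.

The remaining measured step is a number 15.6 percentage points lower from compound 1 to compound 2 (beyond the scatter). All three measured steps exchange the group on an aromatic carbon, and none is a change of configuration alone. The series therefore holds no direct measure of this kind of change. These steps show only that the read-out has moved by modest to large amounts when that group was replaced. Here the atoms and bonds stay the same, so a step of the largest size seen is not the central expectation. Compound 3 at 18.5% sits low on the scale, leaving more room upward than downward.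

The expected step is small and tilted upward: a number 5.5 percentage points higher from compound 3 to compound 4 (within the scatter). For compound 4 the estimate is 24%, with an expected range of 9% to 45%.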

Compound 4, percent of the compound remaining: 28.2%
Compound 4: middle estimate off by 4.2 percentage points, on the low side, and the stated range covers the measured number.
By their numbers in this assay, from the lowest: compounds 3 and 4 (each within the scatter of the next); then compound 2; then compound 1.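

In this assay, among these compounds, this pair gives the first measure of a change of configuration alone at this saturated ring carbon, and the step stays within the scatter (a number 9.7 percentage points higher from compound 3 to compound 4 (within the scatter)), so this read-out does not separate the S and R forms as drawn. The exchange of group keeps its weight with the other configuration: compound 4 also lies beyond the scatter from the compound carrying 4-aminopiperidin-1-yl (a number 42.1 percentage points lower from compound 1 to compound 4 (beyond the scatter)) and from the compound carrying the group with two five-membered rings (a number 26.5 percentage points lower from compound 2 to compound 4 (beyond the scatter)), as compound 3 does. Within these compounds, then, the gaps to compound 1 and compound 2 go with the replaced group and not with the drawn configuration at this stereocentre, a reading that rests on one structural fact: the fact that compounds 3 and 4 differ only in the configuration as drawn.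

Still open, from the compounds shown here alone, is how the read-out would stand with a 4-(dimethylamino)piperidin-1-yl or a 3-aminopyrrolidin-1-yl group on the same aromatic carbon, either of which would separate ring size from the dimethylamino group. Also open, going by these compounds, is whether a change of configuration would stay within the scatter at the other two stereo elements.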